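The source may report more compounds than this note shows. Statements on the series, on what has been measured and on what is new or still open speak of the compounds shown alone.

Measured compounds:
compound 1 `COc1cc(-c2ccc(C)n2-c2ccc(-c3nc4ccccc4s3)cc2)cc(OC)c1OC` with 16000 nM in a functional assay on MDA-MB-231 cells (Homo sapiens) for cytotoxicity, read by MTT assay, with a stated time of 72 h; a higher number here means a weaker inhibitor, a lower number a stronger inhibitor
compound 2 `COc1cc2nc(-c3ccc(-n4c(C)ccc4-c4ccc(C)cc4)cc3)sc2c(OC)c1OC` with 12300 nM in this assay

Compound 2 and compound 1 stand close together on this assay: the two values lie within the scatter of each other, so neither can be placed ahead of the other.

Compound 3 `COc1cc2nc(-c3ccc(-n4c(C)ccc4-c4ccc(F)cc4)cc3)sc2c(OC)c1OC` is the next compound to be read. It differs from compound 2 in one place only: fluoro in place of methyl on an aromatic carbon. Among the compounds with values here, no measured pair in this set shows such an exchange, so there is no recorded step to lean on. Both measured compounds sit in the same region of the assay, and a single-atom exchange of this kind is not expected to move the number by more than the scatter in either direction. Compound 3 is therefore estimated at 14000 nM, with a range from 6000 nM to 33000 nM, and the step from compound 2 to compound 3 is expected to be a 1.1-fold higher number from compound 2 to compound 3 (0.06 log units; within the scatter).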

Compound 3, half-maximal inhibitory concentration: 13100 nM
For compound 3 the middle estimate is 1.1-fold (0.03 log units) above the measured one; the measured number falls inside the stated range.
By their numbers in this assay, from the lowest: compounds 2, 3 and 1 (each within the scatter of the next).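

Within the data shown here, compound 2 and compound 3 give the first measured exchange at this position: in this assay, going from 4-methylphenyl to 4-fluorophenyl gives a 1.1-fold higher number from compound 2 to compound 3 (0.03 log units; within the scatter). Among these compounds, on this ring, at the place para to a large group, methyl and fluoro therefore cannot be told apart in this read-out, a comparison that the earlier compounds, which offered no pair differing in one place, could not provide. No measurement is available here that would account for this result.

The compounds shown leave open whether an amine or a carboxylic acid at the same place would give a number outside the scatter of these two. They also leave open whether the exchange of methyl for fluoro would read the same way on a different core, such as that of compound 1.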